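The source may hold more compounds than are shown below. What is called first, only, known or untested is meant among the compounds shown, and "the series" means these compounds.

Series notes, values from a functional assay on Caco-2 cells (Homo sapiens) for inhibition, read by MTT assay, with a stated time of 48 h, tested at 10 uM; on this read-out lower numbers stand for less inhibition of growth and higher numbers for more inhibition of growth at the one concentration tested:

- compound 1 `Cc1cc(=O)c2c(O)c(CN(C)CC(=O)O)c(O)c([C@H]3CCN(C)C[C@H]3O)c2o1`: 18%
- compound 2 `Cc1cc(=O)c2c(O)c(CN(C(C)C)C(C)C)c(O)c([C@H]3CCN(C)C[C@H]3O)c2o1`: 22%
- compound 3 `Cc1cc(=O)c2c(O)c(CN3CCCC3C(=O)O)c(O)c([C@H]3CCN(C)C[C@H]3O)c2o1`: not yet measured

Compound 2 stands level with compound 1 within the scatter, so neither stands apart on these numbers. The next change gives compound 3: 2-carboxypyrrolidin-1-yl in place of diisopropylamino on a saturated chain carbon bound to an aromatic carbon. The shared core stays the same, and the exchange sits on a saturated chain carbon bound to an aromatic carbon.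

Among the compounds with values here, only one measured step bears on this, a number 4 percentage points higher from compound 1 to compound 2 (within the scatter). It replaced (carboxymethyl)(methyl)amino with diisopropylamino at that same place, and compound 3 again carries a carboxy-bearing amine there. With that single small step as the guide, no shift beyond the scatter is expected in this assay, though one step is a thin basis. The expected step is a number 3 percentage points lower from compound 2 to compound 3 (within the scatter). For compound 3 the estimated value is 19%, with an expected range of 8% to 32%.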

Compound 3, percent growth inhibition at one concentration: 30%
For compound 3 the middle estimate is 11 percentage points below the measured one; measured number inside the range.
By their numbers in this assay, from the lowest: compounds 1, 2 and 3 (each within the scatter of the next, the first and the last beyond it).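

In this assay, this position on a saturated chain carbon bound to an aromatic carbon now gives its first separation beyond the scatter: a number 12 percentage points higher from compound 1 to compound 3 (beyond the scatter) when 2-carboxypyrrolidin-1-yl takes the place of (carboxymethyl)(methyl)amino. Both of these groups carry a carboxy group, so its presence alone does not fix the read-out among the compounds shown, while the exchange for diisopropylamino stays small, with a number 8 percentage points higher from compound 2 to compound 3 (within the scatter) in the same assay. No measurement here accounts for the difference between the two carboxy-bearing amines.

The compounds shown leave open whether the five-membered ring or the carboxy group on it goes with the higher number. An unsubstituted pyrrolidin-1-yl and the methyl ester of the 2-carboxypyrrolidin-1-yl group at this place would separate those two parts.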